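Ester to Methylamide on the Carbonyl: Compound 3 Expected

The compounds below may be only part of what the source reports. "The series", "measured", "known", "first", "only" and "open" are said of these compounds alone.

Compound 1 `CCCNc1nc(C#Cc2ccc(F)s2)nc2c1ncn2[C@H]1[C@H](O)[C@H](O)[C@]2(C(=O)NC)C[C@H]12`: 10.6 nM
Compound 2 `CCOC(=O)[C@@]12C[C@@H]1[C@@H](n1cnc3c(NC)nc(C#Cc4ccc(F)s4)nc31)[C@H](O)[C@@H]2O`: 625 nM

In an assay on HEK293 cells for displacement of a labelled ligand from adenosine receptor A3 (Mus musculus) (on this read-out lower numbers stand for stronger inhibition and higher numbers for weaker inhibition), compound 2 has the higher of the two numbers, and compound 1 gives a number lower by a margin beyond the usual scatter, although the two structures differ in more than one place. Compound 3 `CNC(=O)[C@@]12C[C@@H]1[C@@H](n1cnc3c(NC)nc(C#Cc4ccc(F)s4)nc31)[C@H](O)[C@@H]2O` has not yet been measured. It differs from compound 2 by methylamino in place of ethoxy on a carbonyl carbon. Going by the values given here, no single-change step between measured compounds covers this exchange, so any expectation rests on compound 1, which carries the methylcarbamoyl group and gives 10.6 nM. Compound 3 is therefore expected to give a lower number than compound 2. The expected step is a 13-fold lower number from compound 2 to compound 3 (1.10 log units; beyond the scatter). The estimate for compound 3 is 50 nM, with a range from 10 nM to 250 nM.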

Compound 3, inhibition constant: 85 nM
Compound 3: middle estimate off by 1.7-fold (0.23 log units), on the low side, and the stated range covers the measured number.
By their numbers in this assay, from the lowest: compound 1; then compound 3; then compound 2.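

In this assay the exchange of ethoxycarbonyl to methylcarbamoyl now has its own reading: a 7.4-fold lower number from compound 2 to compound 3 (0.87 log units; beyond the scatter) on the carbonyl carbon. The other place has one too, since hydrogen in place of ethyl on a saturated chain carbon bound to a nitrogen on an aromatic ring gives an 8.0-fold higher number from compound 1 to compound 3 (0.90 log units; beyond the scatter) in the same assay, so each place carries a step beyond the scatter. Nothing available explains either step. Still open, on these data alone, is how a carboxylic acid or an ethylamino group on that carbonyl carbon would read, and whether the carbonyl step keeps its size with the longer chain of compound 1 in place.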